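Bromo to methoxy swap on the aryl isoxazole arm

The compounds below may be only part of what the source reports. "The series", "measured", "known", "first", "only" and "open" are said of these compounds alone.

Measured so far:
compound 1 `O=[N+]([O-])c1ccc(CN2CCC(n3cc(CC(OCc4cc(-c5cccc(Br)c5)no4)c4ccc(Br)cc4)nn3)CC2)cc1`: 6000 nM
compound 2 `N#Cc1cccc(-c2cc(COC(Cc3cn(C4CCN(Cc5ccc([N+](=O)[O-])cc5)CC4)nn3)c3ccc(Br)cc3)on2)c1`: 2000 nM
compound 3 `O=[N+]([O-])c1ccc(CN2CCC(n3cc(CC(OCc4cc(-c5ccccc5Br)no4)c4ccc(Br)cc4)nn3)CC2)cc1`: 6000 nM

In a functional assay on MCF7 cells (Homo sapiens) for cytotoxicity, with a stated time of 48 h (on this read-out lower numbers stand for stronger inhibition and higher numbers for weaker inhibition), compound 3 gives 6000 nM and stands level with compound 1, the two together giving the highest numbers of the three. The step of no change at the digits printed from compound 1 to compound 3 (within the scatter) shows that moving the bromine from 3-bromophenyl to 2-bromophenyl leaves the read-out where it was. Among the compounds with values here, the only step that moves the number is a 3.0-fold lower number from compound 1 to compound 2 (0.48 log units; beyond the scatter), in which cyano replaces bromo on the aromatic carbon.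

Compound 4 `COc1ccccc1-c1cc(COC(Cc2cn(C3CCN(Cc4ccc([N+](=O)[O-])cc4)CC3)nn2)c2ccc(Br)cc2)on1` differs from compound 3 by methoxy in place of bromo on an aromatic carbon. Within the data shown here, no measured pair tests a methoxy group, and the one substitution that changed the number, a 3.0-fold lower number from compound 1 to compound 2 (0.48 log units; beyond the scatter), sits at a different carbon of the ring. What is known is that this aryl position tolerates a moved bromine without effect. The expected step in this assay is therefore small, most likely within the scatter, with a slight lean towards a lower number by analogy with a 3.0-fold lower number from compound 1 to compound 2 (0.48 log units; beyond the scatter). For compound 4 the estimate in this assay is 5000 nM, with a range of 2000 nM to 12000 nM, which means an expected step of a 1.2-fold lower number from compound 3 to compound 4 (0.08 log units; within the scatter).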

Compound 4, half-maximal inhibitory concentration: 3000 nM
Compound 4: the middle estimate sits 1.7-fold (0.22 log units) above what was measured; low and high end bracket the measured number.
By their numbers in this assay, from the lowest: compounds 2, 4, 1 and 3 (each within the scatter of the next, the first and the last beyond it).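

In this assay, the exchange of 2-bromophenyl for 2-methoxyphenyl gives a 2.0-fold lower number from compound 3 to compound 4 (0.30 log units; within the scatter), which shows that this aromatic carbon accepts a methoxy group, with its one hydrogen-bond acceptor, in place of bromo without a step beyond the scatter. The new compound also fails to separate from either of the other two aryl arms, with a 1.5-fold higher number from compound 2 to compound 4 (0.18 log units; within the scatter) and a 2.0-fold lower number from compound 1 to compound 4 (0.30 log units; within the scatter), so it lies within the scatter of both the compounds at the two ends of the earlier step, even though those two differ beyond the scatter from each other. The data shown offer no independent measurement that could explain any of these steps.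

From the compounds shown here alone, it remains open whether a methoxy group would read the same on the ring carbon that carries the bromine in compound 1, and so whether the placement of the substituent matters for anything other than bromo. Also open, going by these compounds, is how this aryl arm would behave in this assay with an amine or a carboxylic acid on the ring, or with no substituent at all.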